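Side chain change from compound 3 to compound 4

The source may report more compounds than this note shows. Statements on the series, on what has been measured and on what is new or still open speak of the compounds shown alone.

In a functional assay on KG-1 cells (Homo sapiens) for antiproliferative activity, read by CCK-8 assay, with a stated time of 72 h (a higher number here means a weaker inhibitor, a lower number a stronger inhibitor), compound 1 `Cc1ccc(C(=O)Nc2cccc(C(F)(F)F)c2)cc1-c1ccc2c(-c3ccc(N4CCN(C)CC4)cc3)n[nH]c2c1` gives 136 nM, compound 2 `Cc1ccc(C(=O)Nc2cccc(C(F)(F)F)c2)cc1-c1ccc2c(-c3ccc(CN4CCN(C)CC4)cc3)n[nH]c2c1` gives 120 nM, and compound 3 `CCCn1cc(-c2n[nH]c3cc(-c4cc(C(=O)Nc5cccc(C(F)(F)F)c5)ccc4C)ccc23)cn1` gives 358 nM. Compound 3 therefore has the highest number of the three, and its gaps to compound 1 and compound 2 lie beyond the scatter.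

Compound 4 `Cc1ccc(C(=O)Nc2cccc(C(F)(F)F)c2)cc1-c1ccc2c(-c3cnn(CC(=O)N(C)C)c3)n[nH]c2c1` differs from compound 3 by one change: dimethylcarbamoyl in place of ethyl on a saturated chain carbon bound to an aromatic nitrogen. In words, dimethylcarbamoyl replaces ethyl on a saturated chain carbon bound to an aromatic nitrogen, which turns propyl into (dimethylcarbamoyl)methyl.

Going by the values given here, the only measured step is a 1.1-fold lower number from compound 1 to compound 2 (0.05 log units; within the scatter), where (4-methylpiperazin-1-yl)methyl takes the place of 4-methylpiperazin-1-yl on an aromatic carbon. That step involves different groups at a different kind of place, so it bears on this change only loosely. Among the compounds with values here, no measured pair covers the change itself.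

With so little to go on, the expectation stays close to compound 3 at 358 nM, with a slight lean toward the lower numbers of the other two compounds. The expected size of the step is a 1.3-fold lower number from compound 3 to compound 4 (0.11 log units; within the scatter), and no step beyond the scatter is firmly expected. The estimate for compound 4 is 280 nM, with an expected range of 100 nM to 750 nM.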

Compound 4, half-maximal inhibitory concentration: 441 nM
Estimate against measurement, compound 4: 1.6-fold (0.20 log units) below; the range from low to high includes it.
By their numbers in this assay, from the lowest: compounds 2 and 1 (each within the scatter of the next); then compounds 3 and 4 (each within the scatter of the next).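

In this assay, dimethylcarbamoyl in place of ethyl on a saturated chain carbon bound to an aromatic nitrogen gives a 1.2-fold higher number from compound 3 to compound 4 (0.09 log units; within the scatter) in this series. The earlier compounds shown here offered no pair at this place, and this one shows that a group of 5 heavy atoms, carrying a carbonyl and a hydrogen-bond acceptor, can replace one of 2 heavy atoms with no difference that this read-out can separate from the scatter. Compound 3 and compound 4 therefore cannot be ranked against each other, and nothing at hand offers an explanation for this outcome.

Going by these compounds, whether this place accepts every kind of group remains open, since a single pair cannot show how far the result extends, and a carboxylic acid, a primary amine or a morpholine on the same carbon could still give a step beyond the scatter. On these data alone, a longer chain between the aromatic nitrogen and the carbonyl, or a secondary amide with the amide hydrogen kept, is also open.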